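The source may report more compounds than this note shows. Statements on the series, on what has been measured and on what is new or still open speak of the compounds shown alone.

Working notes on cytotoxicity in the series. Compound 1 `CCCCn1cc(C(=O)NCc2ccc(OC)c([N+](=O)[O-])c2)c(=O)c2cc(F)c(N3CCC(C(N)=O)CC3)cc21` is tested in an ADME assay on J774.1 cells (Mus musculus) for cytotoxicity, read by resazurin assay, with a stated time of 48 h; on this read-out lower numbers stand for stronger inhibition and higher numbers for weaker inhibition. In this assay compound 1 gives > 100000 nM, which is a limit of the assay and not a number. Compound 2 `NC(=O)C1CCN(c2cc3c(cc2F)c(=O)c(C(=O)NCc2ccco2)cn3C2CC2)CC1` belongs to the same set. In this assay compound 2 gives > 100000 nM, again a limit rather than a number. Compound 1 thus stands at the limit shared by both values shown, (the limit of > 100000 nM in this assay, at which 2 of the 2 values shown sit); no ordering between the two compounds can be read from this.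

Compound 3 `CCCCn1cc(C(=O)NCc2ccccc2)c(=O)c2cc(F)c(N3CCC(C(N)=O)CC3)cc21` is not yet measured in this assay. Against compound 1 it shows (phenyl in place of 4-methoxy-3-nitrophenyl on a saturated chain carbon bound to an amide-type nitrogen), a change on the amide side of the shared core with the rest of compound 1 kept. Within the data shown here, no step between two measured compounds is available to set the size of such a change. With both measured values sitting at the limit, the step expected is a step that the limit leaves unreadable from compound 1 to compound 3, none beyond the scatter, and the read-out is most likely again a limit. The value expected for compound 3 in this assay is 150000 nM, within 70000 nM to 300000 nM.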

Compound 3, half-maximal inhibitory concentration: 47000 nM
Beside the measured number, compound 3's estimate is 3.2-fold (0.50 log units) above it; the whole stated range lies above it.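

Among these compounds, compound 3 gives the first reading in this assay that is a number and not a limit, so cytotoxicity can be brought into the measurable range with the butyl chain and the shared core kept. The place on the saturated chain carbon bound to the amide-type nitrogen therefore responds to substitution: going from 4-methoxy-3-nitrobenzyl to benzyl gives an at least 2.1-fold lower number from compound 1 to compound 3 (0.32 log units; beyond the scatter), a change beyond the scatter and in the direction of stronger inhibition on this read-out. The step is a minimum and its true size stays unknown, as the value it starts from is a limit: the limit of > 100000 nM in this assay, at which 2 of the 3 values shown sit.

The compounds shown leave open whether the methoxy or the nitro group accounts for the step, which a benzyl carrying only one of the two, or a benzyl carrying an amine or a carboxylic acid, would help to separate. Compound 2 differs from compound 3 in more than one place, so the part played by the furan-bearing amide side or by the cyclopropyl group in place of the butyl chain also remains unsettled.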